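Phenoxy for Methoxyethoxy on a Shared Anilinotriazine Core

The source may report more compounds than this note shows. Statements on the series, on what has been measured and on what is new or still open speak of the compounds shown alone.

The series is followed in a functional assay on Ramos cells (Homo sapiens) for antiproliferative activity, read by CCK-8 assay, with a stated time of 24 h; on this read-out higher numbers stand for weaker inhibition and lower numbers for stronger inhibition. Compound 1 `C=CC(=O)Nc1cccc(Nc2nc(Cl)nc(Nc3ccc(OCCOC)cc3)n2)c1` has no number in this assay, its entry reading "not determined" (no result reported). Compound 2 `C=CC(=O)Nc1cccc(Nc2ncnc(Nc3ccc(C(=O)Nc4ccccn4)cc3)n2)c1` likewise stands without a result, its entry reading "not determined" (no result reported). Within the data shown here, the only measured member is compound 3 `C/C=C/C(=O)Nc1cccc(Nc2ncnc(Nc3ccc(C(=O)N4CCCCC4)cc3)n2)c1`, which in this assay gives 13200 nM; compound 3 differs from compound 1 in several places at once, so no single step between measured compounds can be computed.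

Compound 4 `C=CC(=O)Nc1cccc(Nc2nc(Cl)nc(Nc3ccc(Oc4ccccc4)cc3)n2)c1` is the unmeasured analogue. It differs from compound 1 by phenyl in place of 2-methoxyethyl on an oxygen on an aromatic ring. Among the measured compounds shown here, with no numerical value for compound 1 and no step between measured compounds, the direction and size of the change cannot be read from the data; any expectation rests only on compound 3 and its value of 13200 nM as the sole anchor, and must be treated as broad.

On that basis compound 4 is estimated to give 6000 nM in this assay, with an expected range from 600 nM to 60000 nM.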

Compound 4, half-maximal inhibitory concentration: 12300 nM
For compound 4 the middle estimate is 2.1-fold (0.31 log units) below the measured one; measured number inside the range.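

No step can be read from compound 1 to compound 4 in this assay, since compound 1 has no single number there. The compounds shown leave open how replacing 2-methoxyethoxy with phenoxy shifts the result in this assay. Nothing given here bears on the value of compound 4.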